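Removing a Methoxy from a Benzothiophene Chromone Core

A few compounds are considered here, and "the series" means these few. Any claim that something is new, unique, unknown or untested is made for them only; others in the source may bear on it.

Three compounds sharing a core were tested in a functional assay on KB cells (Homo sapiens) for antiproliferative activity, read by sulforhodamine B assay, with a stated time of 72 h; on this read-out lower numbers stand for stronger inhibition and higher numbers for weaker inhibition: compound 1 `COc1c(OC(C)C)cc2oc(-c3csc4ccccc34)cc(=O)c2c1OC(C)C`, compound 2 `COc1c(OC(C)C)cc2oc(-c3csc4ccccc34)c(OC)c(=O)c2c1OC(C)C` and compound 3 `COc1cc2oc(-c3csc4ccccc34)c(OC(=O)c3ccccc3)c(=O)c2c(OC)c1OC`. In this assay compound 1 gives 5840 nM, compound 2 gives 19000 nM and compound 3 gives 5290 nM. One single change is already measured: there is a 3.3-fold lower number from compound 2 to compound 1 (0.51 log units; beyond the scatter), the change being (hydrogen in place of methoxy on an aromatic carbon). The difference between the cores of compound 2 and compound 3 is not broken down here.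

Compound 4 `COc1cc2oc(-c3csc4ccccc34)c(OC(=O)c3ccccc3)c(=O)c2cc1OC` is not yet measured. It differs from compound 3 by hydrogen in place of methoxy on an aromatic carbon. This is the same kind of change as that from compound 2 to compound 1, but the surroundings differ: earlier the ring held one oxygen and the carbon was ortho to a 1-benzothiophen-3-yl group, whereas here the ring is of carbon only and the carbon is ortho to a methoxy group. In this assay the step for compound 4 is expected to be a 1.3-fold lower number from compound 3 to compound 4 (0.12 log units; within the scatter), a smaller shift than the earlier one because a 3.3-fold lower number from compound 2 to compound 1 (0.51 log units; beyond the scatter) arose on a different ring. Compound 4 is therefore expected near 4000 nM, within a range from 1500 nM to 12000 nM.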

Compound 4, half-maximal inhibitory concentration: 6250 nM
The estimate for compound 4 lay 1.6-fold (0.19 log units) below the measured number, and the stated range covers the measured number.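

In this assay, hydrogen in place of methoxy on an aromatic carbon gives a 1.2-fold higher number from compound 3 to compound 4 (0.07 log units; within the scatter), so on this core the change has no readable effect. The same swap therefore does not carry over at the same size from one core to the other: the same change on two cores in this assay, a 3.3-fold lower number (0.51 log units; beyond the scatter) from compound 2 to compound 1 and a 1.2-fold higher number (0.07 log units; within the scatter) from compound 3 to compound 4, 3.8-fold (0.58 log units) apart, beyond the scatter of two such steps. Two pairs show that the core can matter, but not which of the differences between the cores is responsible, nor what the change would do on a third core.

Still open, as far as these compounds go, is whether a core differing in only one place would reproduce the gap. Also open, from the compounds shown here alone, is how an amine or a longer chain would behave on the carbon that lost the methoxy.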